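The source may report more compounds than this note shows. Statements on the series, on what has been measured and on what is new or still open speak of the compounds shown alone.

Working notes on the acyl series sharing the core of compound 1 `CCC(=O)Nc1c(C(O)(C(F)(F)F)C(F)(F)F)ccc2ccccc12`. In an assay on LtK cells with ATP-sensitive inward rectifier potassium channel 11 (Homo sapiens) as the target (on this read-out lower numbers stand for an effect already at smaller amounts and higher numbers for an effect only at larger amounts of compound), compound 1 gives 15 nM, the lowest of the three numbers obtained so far. Compound 2 `CC(C)=CC(=O)Nc1c(C(O)(C(F)(F)F)C(F)(F)F)ccc2ccccc12` gives 46 nM and compound 3 `O=C(Nc1c(C(O)(C(F)(F)F)C(F)(F)F)ccc2ccccc12)C1CCC1` gives 45 nM; the two steps away from compound 1 read a 3.1-fold higher number from compound 1 to compound 2 (0.49 log units; beyond the scatter) and a 3.0-fold higher number from compound 1 to compound 3 (0.48 log units; beyond the scatter), while the pair compound 2 and compound 3 shows a 1.0-fold lower number from compound 2 to compound 3 (0.01 log units; within the scatter).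

Compound 4 `O=C(CCc1ccccc1)Nc1c(C(O)(C(F)(F)F)C(F)(F)F)ccc2ccccc12` is not yet measured. It differs from compound 1 by phenyl in place of hydrogen on a saturated chain carbon, two bonds along the chain from a carbonyl carbon. Going by the values given here, no measured step matches this change directly; the nearest guides are the two enlargements of the acyl group, from compound 1 to compound 2 and from compound 1 to compound 3, which both moved this assay by a modest amount in the same direction. Compound 4 carries a larger extension than either, so a step of similar or somewhat greater size, towards a higher number, is expected, though the scatter leaves room for a null result. The estimated step is a 3.0-fold higher number from compound 1 to compound 4 (0.48 log units; beyond the scatter). Compound 4 is therefore expected to give about 45 nM, with a range from 15 nM to 150 nM.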

Compound 4, half-maximal effective concentration: 1750 nM
Compound 4: middle estimate off by 39-fold (1.59 log units), on the low side; the measured number lies above the stated range.
By their numbers in this assay, from the lowest: compound 1; then compounds 3 and 2 (each within the scatter of the next); then compound 4.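

In this assay, phenyl on a saturated chain carbon, two bonds along the chain from a carbonyl carbon, gives a 120-fold higher number from compound 1 to compound 4 (2.07 log units; beyond the scatter), so enlarging the acyl group here need not cost only the modest amount seen with the earlier changes. The phenethyl group also stands well apart from the two other enlarged acyl groups, with a 39-fold higher number from compound 3 to compound 4 (1.59 log units; beyond the scatter) and a 38-fold higher number from compound 2 to compound 4 (1.58 log units; beyond the scatter), whereas cyclobutyl and 2-methylprop-1-en-1-yl lie within the scatter of each other. No supporting data bear on the reason for this step.

The compounds shown leave open whether the step follows from the phenyl ring itself or from the overall size of the acyl group. A pentanoyl group, with a longer chain and no ring, and a phenylacetyl group, with a shorter link to the phenyl, would help separate the two.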